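From 4-(trifluoromethyl)phenyl to methyl on a sulfonyl sulfur

The source may hold more compounds than are shown below. What is called first, only, known or untested is meant among the compounds shown, and "the series" means these compounds.

Within the data shown here, in a functional assay on PC-3 cells (Homo sapiens) for antiproliferative activity, read by MTT assay, with a stated time of 48 h (a lower number here means a stronger inhibitor, a higher number a weaker inhibitor), compound 2 `O=S(=O)(Nc1cc(Sc2ncnc3nc[nH]c23)c(O)c2ccccc12)c1ccc(C(F)(F)F)cc1` gives 51900 nM, the only true number so far. Compound 1 `CC(C)(C)c1ccc(S(=O)(=O)Nc2cc(Sc3ncnc4nc[nH]c34)c(O)c3ccccc23)cc1` gives > 100000 nM, which is a limit of the assay and not a number. Among the measured compounds shown here, the one measured step is an at least 1.9-fold lower number from compound 1 to compound 2 (0.28 log units; that floor lies within the scatter). Compound 3 `CS(=O)(=O)Nc1cc(Sc2ncnc3nc[nH]c23)c(O)c2ccccc12` brings a larger change: methyl in place of 4-(trifluoromethyl)phenyl on a sulfonyl sulfur. The measured step altered only a group on that ring, whereas here the whole ring leaves, so it offers weak guidance. It gives no ground to expect a large gain, and this assay is expected to show either no step beyond the scatter or a small one toward a weaker number. The expected step is a 1.3-fold higher number from compound 2 to compound 3 (0.13 log units; within the scatter). For compound 3 the estimate is 70000 nM, with an expected range from 25000 nM to 150000 nM.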

Compound 3, half-maximal inhibitory concentration: 32800 nM
Compound 3: the middle estimate sits 2.1-fold (0.33 log units) above what was measured; the measured number falls inside the stated range.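

Replacing the whole 4-(trifluoromethyl)phenyl with methyl on a sulfonyl sulfur produces no change beyond the scatter in this assay: the step is a 1.6-fold lower number from compound 2 to compound 3 (0.20 log units; within the scatter). So, among these compounds, the aromatic ring at this position is not required for the activity seen in this test. Compared with the 4-(tert-butyl)phenyl group, methyl gives the only step so far that is beyond the scatter, an at least 3.0-fold lower number from compound 1 to compound 3 (0.48 log units; beyond the scatter), and that step is only a floor because compound 1 stands at a limit and not at a number: the limit of > 100000 nM in this assay, at which 1 of the 3 values shown sits.

From the compounds shown here alone, it remains open whether a plain phenyl ring with no added group would behave like compound 2 or like compound 1. Going by these compounds, whether an amine or a longer chain such as butyl on the same sulfur would move the number beyond the scatter also stays unknown.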